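The compounds below may be only part of what the source reports. "The series", "measured", "known", "first", "only" and "open" are said of these compounds alone.

Of the compounds shown here, three of this set have been measured in an assay on isolated protein for inhibition of lysosomal alpha-glucosidase (Rattus norvegicus), read by spectrophotometry, with a stated time of 5 min, tested at 25 ug/mL; a lower number here means less inhibition, a higher number more inhibition at the concentration tested (going by the name of the read-out). Compound 1 `O=C(/C=C/c1ccc(O)c(O)c1)c1cc2ccoc2cc1O` gives 62.7% there. Compound 2 `COc1cc(OC)c(OC)cc1/C=C/C(=O)c1cc2ccoc2cc1O` gives 68%, and compound 3 `COc1ccc(/C=C/C(=O)c2ccc3occc3c2O)c(OC)c1OC` gives 67.3%. The three numbers sit close together: the gap between compound 1 and compound 3 is within the usual scatter of repeated measurements, and so is the gap between compound 1 and compound 2. Compound 1 therefore stands among its two companions rather than apart from them, and nothing in these three numbers separates any one of them from the others.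

Compound 4 `COc1cc(/C=C/C(=O)c2cc3ccoc3cc2O)ccc1O` has not yet been measured in this assay. It differs from compound 1 in one place: methyl in place of hydrogen on an oxygen on an aromatic ring. Compounds 2 and 3 carry methoxy groups rather than hydroxy groups on the ring of the unsaturated ketone, and their numbers in this assay are no different from that of compound 1 beyond the scatter, so a step of similar kind in compound 4 is expected to be small, with no direction that can be told from these three numbers. The expected step from compound 1 to compound 4 is a number 2.3 percentage points higher from compound 1 to compound 4 (within the scatter). Compound 4 is estimated to give 65% in this assay, within a range from 52% to 78%.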

Compound 4, a percentage reported as inhibition, at one concentration (the size of the read-out at that concentration, not a potency): 52.8%
For compound 4 the middle estimate is 12.2 percentage points above the measured one, within the range that was stated.
By their numbers in this assay, from the lowest: compounds 4, 1, 3 and 2 (each within the scatter of the next, the first and the last beyond it).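

Within the data shown here, this is the first step in this assay that can be read between two compounds differing in one place: hydroxy to methoxy, with methyl in place of hydrogen on an oxygen on an aromatic ring, amounts to a number 9.9 percentage points lower from compound 1 to compound 4 (within the scatter), so this single change does not move the number clearly beyond what repeated measurement could give. The earlier compounds shown here could offer only a loose comparison, as compound 2 and compound 3 differ from compound 1 in more than one place, whereas this step isolates the change at this one oxygen and shows no clear need for the hydrogen there at the concentration tested. Nothing measured here offers an explanation for the size of this step.

The compounds shown leave open whether the same change on the other hydroxy group of compound 1 would give a similar step. They also leave open whether a longer chain such as ethyl on this oxygen, or an amine in place of the hydroxy group, would move the number beyond the scatter.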